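Cycloheptyl in place of 2-chlorophenyl at the aryl end

This account rests on a few compounds, and the source may have more. Where it says the series, first, only, none or still open, it means among the compounds named here.

Measured so far in an in vitro functional assay on cells for agonist activity at Bombesin receptor subtype-3 (Mus musculus), read by luminescence and calcium flux; a lower number here means that less compound is needed, a higher number that more compound is needed for the effect:
compound 1 `CCCCc1cnc(C(Cc2ccc(-c3ccccc3C(=O)O)cc2)C(C)C)[nH]1`: 2240 nM
compound 2 `O=C(O)c1ccccc1-c1ccc(CCc2ncc(Cc3ccccc3Cl)[nH]2)cc1`: 22 nM
compound 3 `CCCCc1cnc(C(CC)Cc2ccc(-c3ccccc3C(=O)O)cc2)[nH]1`: 340 nM

Compound 2 stands lowest of the three in this assay; the nearest value is that of compound 3, the furthest that of compound 1, both beyond the scatter. Within the data shown here, the step of a 6.6-fold lower number from compound 1 to compound 3 (0.82 log units; beyond the scatter) is the only measured step, and it sits on the chain, not on the group that changes here, so it bears little on the present question.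

Compound 4 `O=C(O)c1ccccc1-c1ccc(CCc2ncc(CC3CCCCCC3)[nH]2)cc1` differs from compound 2 by cycloheptyl in place of 2-chlorophenyl on a saturated chain carbon bound to an aromatic carbon. Among the measured compounds shown here, no measured step touches this group, so the expectation rests on compound 2 alone and is held wide. Compound 4 is expected to give 60 nM in this assay, within 12 nM to 300 nM, the estimated step being a 2.7-fold higher number from compound 2 to compound 4 (0.44 log units; beyond the scatter).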

Compound 4, half-maximal effective concentration: 5.7 nM
Compound 4: middle estimate off by 11-fold (1.02 log units), on the high side; the measured number lies below the stated range.
By their numbers in this assay, from the lowest: compound 4; then compound 2; then compound 3; then compound 1.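

In this assay the aryl end does not need an aromatic ring or a chlorine: cycloheptyl in place of 2-chlorophenyl gives a 3.9-fold lower number from compound 2 to compound 4 (0.59 log units; beyond the scatter) and so improves on the lowest earlier number. This single pair changes ring size and aromatic character together, and the two cannot be separated here. Nothing available explains the step.

Still open, going by these compounds, is whether cyclohexyl or cyclopentyl would match cycloheptyl at this position. Also open, on these data alone, is whether a phenyl without the chlorine or a ring carrying an amine would hold the number.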